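Aryl Variation on the Shared Core: Formyl Substituent

The source may hold more compounds than are shown below. What is called first, only, known or untested is meant among the compounds shown, and "the series" means these compounds.

The series shares the core of compound 1 `CCc1ccc(-c2cn3ccnc3c(-c3ccc4ncn(Cc5ccccc5)c4c3)n2)cc1` and varies the aryl group attached to it. In a functional assay on NCI-H226 cells (Homo sapiens) for inhibition, read by sulforhodamine B assay, with a stated time of 48 h, tested at 10 uM (a lower number here means less inhibition, a higher number more inhibition at the concentration tested (going by the name of the read-out)), compound 1 gives 1.48%. Compound 2 `Cc1cccc(-c2cn3ccnc3c(-c3ccc4ncn(Cc5ccccc5)c4c3)n2)c1` gives 1.18% in this assay, the lower of the two numbers recorded so far, with compound 1 its nearest neighbour; the step of a number 0.3 percentage points lower from compound 1 to compound 2 (within the scatter) lies within the scatter, so the two compounds are not separated. Compound 3 `O=Cc1ccc(-c2cn3ccnc3c(-c3ccc4ncn(Cc5ccccc5)c4c3)n2)cc1` is not yet measured in this assay. It differs from compound 2 by 4-formylphenyl in place of 3-methylphenyl on an aromatic carbon. Among the measured compounds shown here, the only measured step, a number 0.3 percentage points lower from compound 1 to compound 2 (within the scatter), concerns an exchange of one substituted phenyl for another and shows no movement beyond the scatter; no measured step covers the entry of a carbonyl hydrogen-bond acceptor, so nothing in the data supports a shift in either direction. For compound 3 in this assay the expected step is a number 0.8 percentage points higher from compound 2 to compound 3 (within the scatter), none beyond the scatter. Compound 3 is therefore estimated at 2%, with a range from -8% to 15%.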

Compound 3, a percentage reported as inhibition, at one concentration (the size of the read-out at that concentration, not a potency): 0.53%
For compound 3 the middle estimate is 1.5 percentage points above the measured one; measured number inside the range.
By their numbers in this assay, from the lowest: compounds 3, 2 and 1 (each within the scatter of the next).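

In this assay, the step from the methyl-bearing aryl group to one with a formyl group is a number 0.7 percentage points lower from compound 2 to compound 3 (within the scatter), and the exchange of ethyl for formyl at the same aryl group is a number 1 percentage points lower from compound 1 to compound 3 (within the scatter). Adding a carbonyl and its hydrogen-bond acceptor to this aryl group therefore produces no separation from either hydrocarbon-substituted compound, so 4-ethylphenyl, 3-methylphenyl and 4-formylphenyl cannot be told apart at this aromatic carbon of the shared core. No supporting data bear on this result.

As far as these compounds go, whether a primary amine, a carboxylic acid or a longer alkyl chain on the phenyl ring would give a step beyond the scatter remains open. Also open, from the compounds shown here alone, is whether a change elsewhere on the shared core would move the number at all.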